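Naphthoquinone ethers: furanyl oxygen replaced by crotonyl ester

This account rests on a few compounds, and the source may have more. Where it says the series, first, only, none or still open, it means among the compounds named here.

Of the compounds shown here, two have been read in a functional assay on KB cells (Homo sapiens) for cytotoxicity (a higher number here means a weaker inhibitor, a lower number a stronger inhibitor), so far. Compound 1 `CCOC1=CC(=O)c2ccccc2C1=O` gives 16900 nM in this assay. Among the measured compounds shown here, compound 2 `O=C1C=C(Oc2ccco2)C(=O)c2ccccc21` gives 53400 nM in this assay, the highest of the two numbers; the only step recorded, a 3.2-fold higher number from compound 1 to compound 2 (0.50 log units; beyond the scatter), shows furan-2-yl in place of ethyl on an oxygen on an unsaturated carbon raising the number modestly.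

Compound 3 `C/C=C/C(=O)OC1=CC(=O)c2ccccc2C1=O` carries a change at the same oxygen: (prop-1-en-1-yl)carbonyl in place of furan-2-yl on an oxygen on an unsaturated carbon. For the measured compounds named here, no measured step shows this carbonyl-bearing group entering, so the single step from compound 1 to compound 2 is the only guide, and it points to shifts of modest size at this position in either direction. The estimate for compound 3 is therefore a number near that of compound 2, 30000 nM with a range of 8000 nM to 90000 nM, a step of a 1.8-fold lower number from compound 2 to compound 3 (0.25 log units; within the scatter) that is expected to stay close to the scatter.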

Compound 3, half-maximal inhibitory concentration: 64200 nM
Compound 3: middle estimate off by 2.1-fold (0.33 log units), on the low side, and the stated range covers the measured number.
By their numbers in this assay, from the lowest: compound 1; then compounds 2 and 3 (each within the scatter of the next).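

Replacing the furan-2-yl with the ringless (prop-1-en-1-yl)carbonyl, at the same count of heavy atoms on an oxygen on an unsaturated carbon, gives a 1.2-fold higher number from compound 2 to compound 3 (0.08 log units; within the scatter) in this assay, so these two groups cannot be told apart here. The same group set against ethyl gives a 3.8-fold higher number from compound 1 to compound 3 (0.58 log units; beyond the scatter) and joins the furan-2-yl in reading beyond the scatter from compound 1, which now holds the lowest number of the three compounds. No supporting measurement bears on these readings.

On these data alone, whether a methyl or a longer propyl chain on this oxygen would read lower than compound 1 remains open. Also open, as far as these compounds go, is whether a saturated butanoyl group would read with compound 3 , which would test the double bond of the (prop-1-en-1-yl)carbonyl.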